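The source may report more compounds than this note shows. Statements on the series, on what has been measured and on what is new or still open speak of the compounds shown alone.

The series shares one core, seen in compound 1 `Cc1cn2c(-c3cn[nH]c3)cnc2c(Nc2cc(Cn3cccn3)ns2)n1` and in compound 2 `Cc1cn2c(-c3cn[nH]c3)cnc2c(Nc2cc(Cn3cccc(C)c3=O)ns2)n1`, both of which were examined in an ADME assay on the whole organism for pharmacokinetics, with Rattus norvegicus as the target, with a stated time of 6 h, at a dose of 10 mg/kg by the oral route (a higher number here means more compound in the circulation at the dose given, a lower number less compound in the circulation), without a number being reported: for compound 1 the outcome stands as "not determined" (no result reported), and for compound 2 likewise as "not determined" (no result reported). Going by the values given here, compound 3 `Cc1cn2c(-c3cn[nH]c3)cnc2c(Nc2cc(Cc3nccs3)ns2)n1` is therefore the only member with a figure, and in this assay compound 3 gives 1540 ng.h/mL. Among the compounds with values here, it stands alone; there is no second number against which to rank it, and no step between measured compounds can be read from the set.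

Compound 4 `Cc1cn2c(-c3cn[nH]c3)cnc2c(Nc2cc(Cc3ncccc3C)ns2)n1` differs from compound 3 in one place: 3-methylpyridin-2-yl in place of 1,3-thiazol-2-yl on a saturated chain carbon bound to an aromatic carbon. Within the data shown here, whether this change raises or lowers exposure cannot be drawn from the compounds here, since no comparable step has been measured.

With only the figure for compound 3 as an anchor, compound 4 is expected to land close to it, and the step from compound 3 to compound 4 is estimated as a 1.3-fold lower number from compound 3 to compound 4 (0.11 log units; within the scatter), which would not be a change beyond the scatter of repeated measurements. Compound 4 is estimated to give 1200 ng.h/mL in this assay, with a range from 400 ng.h/mL to 3500 ng.h/mL considered plausible.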

Compound 4, area under the concentration-time curve: 644 ng.h/mL
Compound 4: middle estimate off by 1.9-fold (0.27 log units), on the high side; the range from low to high includes it.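

Moving from 1,3-thiazol-2-yl to 3-methylpyridin-2-yl on a saturated chain carbon bound to an aromatic carbon gives the series its first readable step: in this assay there is a 2.4-fold lower number from compound 3 to compound 4 (0.38 log units; beyond the scatter). This shows that the group held at this place can alter the area under the concentration-time curve at the given oral dose, which the single figure available earlier could not show, and that among these two groups the 1,3-thiazol-2-yl compound has the higher number. No measurement at hand bears on why the number falls.

The steps involving compound 1 and compound 2 cannot be read, as neither compound has a number. Going by these compounds alone, the one change also replaces a five-membered ring with a six-membered ring, swaps the sulfur for carbon and brings in a methyl group all at once, so it remains open whether a plain pyridin-2-yl group, without the methyl, would sit nearer compound 3 or compound 4, or where a 1,3-oxazol-2-yl group would fall.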